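Moving a Bromine Around the Ring: Expected Lipophilicity

The compounds below may be only part of what the source reports. "The series", "measured", "known", "first", "only" and "open" are said of these compounds alone.

Of the compounds shown here, two have been measured so far. Compound 1 `O=C(COc1cccc2ccccc12)N/N=C/c1cccc(O)c1` carries a 3-hydroxyphenyl on a carbon with a double bond to nitrogen; in a physicochemical assay for lipophilicity, measured as octanol-water partition (on this read-out lower numbers stand for lower lipophilicity and higher numbers for higher lipophilicity), compound 1 gives 3.73. Compound 2 `O=C(COc1cccc2ccccc12)N/N=C/c1ccccc1Br` has a 2-bromophenyl in that position, and in this assay compound 2 gives 4.81, the higher of the two numbers. Among the compounds with values here, the one measured step, a number 1.08 log units higher from compound 1 to compound 2 (beyond the scatter), is large and beyond the scatter.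

Compound 3 `O=C(COc1cccc2ccccc12)N/N=C/c1ccc(Br)cc1` is the next compound, not yet measured. It differs from compound 2 only in this: 4-bromophenyl in place of 2-bromophenyl on a carbon with a double bond to nitrogen. Compound 2 and compound 3 are built from the same atoms, joined differently.

The step from compound 1 to compound 2 exchanges a hydroxyphenyl for a bromophenyl, which is a different kind of change from moving a bromine from one ring position to another, so it offers only a loose guide. Within the data shown here, no measured pair in this set moves a group within a ring. Since the change to compound 3 keeps every atom and only relocates the bromine, the expected step in this assay is small, a number 0.09 log units higher from compound 2 to compound 3 (within the scatter), within the scatter. For compound 3 the estimate in this assay is 4.9, with a range from 4.5 to 5.3.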

Compound 3, partition coefficient: 4.81
Compound 3: middle estimate off by 0.09 log units, on the high side; measured number inside the range.
By their numbers in this assay, from the lowest: compound 1; then compounds 2 and 3 (each within the scatter of the next).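

In this assay, replacing the 2-bromophenyl with a 4-bromophenyl on the carbon with a double bond to nitrogen gives no change at the digits printed from compound 2 to compound 3 (within the scatter), so this read-out does not separate these two bromophenyl groups. Within the data shown here, this is the first view of a group moved within a ring at this place, and the large step seen earlier does not depend on which of the two bromophenyl groups enters: exchanging the 3-hydroxyphenyl for the 4-bromophenyl gives a number 1.08 log units higher from compound 1 to compound 3 (beyond the scatter), matching the earlier step with the 2-bromophenyl. The data offer no independent measurement that explains why compound 2 and compound 3 agree.

The compounds shown cover only one hydroxyphenyl and two bromophenyl groups at this place, so they do not tell whether a phenyl ring carrying chlorine, an amine or a carboxylic acid would fall nearer to compound 1 or to compound 2. They also leave open whether the agreement between these two bromophenyl groups would hold if the shared core were changed, for example by a longer chain in its linker.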